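This account rests on a few compounds, and the source may have more. Where it says the series, first, only, none or still open, it means among the compounds named here.

Measured compounds:
compound 1 `COc1cccc(-c2cc(COc3ccc4oc(=O)ccc4c3)on2)c1`, "not determined" (no result reported) in a functional assay on PC-3 cells (Homo sapiens) for cytotoxicity, read by MTT assay, with a stated time of 48 h; a higher number here means a weaker inhibitor, a lower number a stronger inhibitor;
compound 2 `O=c1ccc2cc(OCc3cc(-c4ccccc4[N+](=O)[O-])no3)ccc2o1`, 8200 nM;
compound 3 `O=c1ccc2cc(OCc3cc(-c4ccc([N+](=O)[O-])cc4)no3)ccc2o1`, "not determined" (no result reported).

Within the data shown here, compound 3 stands without a number in this assay, and compound 1 likewise has none, so the only value at hand comes from compound 2, which gives 8200 nM. Compound 4 `COc1ccccc1-c1cc(COc2ccc3oc(=O)ccc3c2)on1` differs from compound 3 by 2-methoxyphenyl in place of 4-nitrophenyl on an aromatic carbon. Among the measured compounds shown here, since compound 3 carries no value, no step can be attached to this change, and the account has to lean on compound 2 alone. Compound 4 is expected to fall in the same region as compound 2, with no shift beyond the usual scatter of this assay foreseen. Compound 4 is estimated at 10000 nM, within a range from 3000 nM to 40000 nM.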

Compound 4, half-maximal inhibitory concentration: 22400 nM
The estimate for compound 4 lay 2.2-fold (0.35 log units) below the measured number; the range from low to high includes it.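

Among these compounds, this result gives the first comparison at this position: in this assay, methoxy in place of nitro on an aromatic carbon gives a 2.7-fold higher number from compound 2 to compound 4 (0.44 log units; beyond the scatter), so the number responds to this change of group on the phenyl ring. The step from compound 3 to compound 4 cannot be read, as compound 3 has no number. Nothing given here explains the step.

Still open, going by these compounds, is whether the 4-nitrophenyl of compound 3 would differ from compound 2 at all. Also open, on these data alone, is how an amine or a carboxylic acid in place of methoxy or nitro would read.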